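Amino in place of phenyl: an untested step

The source may report more compounds than this note shows. Statements on the series, on what has been measured and on what is new or still open speak of the compounds shown alone.

Compound 1 `Cc1c(-n2c(-c3ccccc3)c(-c3ccccc3)c3c(Nc4ccccc4)ncnc32)n(C)n(-c2ccccc2)c1=O` gives 13% in a functional assay on the whole organism (strain Sprague-Dawley) for inhibition, with Rattus norvegicus as the target, read by paw edema, with stated times of 1 h and 3 h, at a dose of 70 mg/kg by the subcutaneous route (on this read-out higher numbers stand for more inhibition at the one dose given (going by the name of the read-out) and lower numbers for less inhibition), the lowest of the three numbers shown. Compound 2 `Cc1nc2c(c(-c3ccccc3)c(-c3ccccc3)n2-c2c(C)c(=O)n(-c3ccccc3)n2C)c(=O)[nH]1` gives 13.2% in this assay, a figure within the scatter of compound 1, so the two cannot be ordered. Compound 3 `Cc1c(-n2c(N)c(C(N)=O)c(-c3ccccc3)c2-c2ccccc2)n(C)n(-c2ccccc2)c1=O` gives 47.8% in this assay, a value beyond the scatter above compound 1. The untested compound 4 `Cc1c(-n2c(-c3ccccc3)c(-c3ccccc3)c3c(NN)ncnc32)n(C)n(-c2ccccc2)c1=O` differs from compound 1 in one place: amino in place of phenyl on a nitrogen on an aromatic ring. Within the data shown here, no measured pair shows this change, so its effect in this assay is unknown. Among the measured compounds shown here, with compound 3 at 47.8% as the only compound here bearing an amino group, a modest rise is expected, one that may still sit within the scatter. The expected step is a number 9 percentage points higher from compound 1 to compound 4 (within the scatter). Compound 4 is therefore estimated at 22%, with a range from 6% to 45%.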

Compound 4, a percentage reported as inhibition, in the whole organism at one dose (the size of the read-out at that dose, not a potency): 65.1%
Beside the measured number, compound 4's estimate is 43.1 percentage points below it; measured number outside the range, above it.
By their numbers in this assay, from the lowest: compounds 1 and 2 (each within the scatter of the next); then compound 3; then compound 4.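

Amino in place of phenyl on a nitrogen on an aromatic ring gives a number 52.1 percentage points higher from compound 1 to compound 4 (beyond the scatter) in this assay and so shows that this position does not need the phenyl ring and that anilino to aminoamino can bring a large gain. This single pair gives the size of the step, but nothing here explains it.

Open, as far as these compounds go, is whether the gain needs the whole aminoamino group, since a plain amine or a methylamino group in its place would test that. Open too, from the compounds shown here alone, is whether larger groups, such as an acetyl on the outer nitrogen, would keep the gain.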